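The compounds below may be only part of what the source reports. "The series", "measured", "known", "first", "only" and "open" are said of these compounds alone.

Of the compounds shown here, three have been measured in a functional assay on CHO cells for antagonist activity at sphingosine 1-phosphate receptor 2 (Homo sapiens), read by GTPgammaS binding; on this read-out lower numbers stand for stronger inhibition and higher numbers for weaker inhibition. Compound 1 `CCn1nc(CC(=O)Nc2ccc(OC(F)(F)F)c(Cl)c2)c2ccccc2c1=O` gives 473 nM, the highest of the three numbers. Compound 3 `O=C(O)Cn1nc(Cc2nc3cc(Cl)c(OC(F)(F)F)cc3[nH]2)c2ccccc2c1=O` gives 342 nM, a figure that lies within the usual scatter of the number for compound 1, so no order between the two can be claimed. Compound 2 `O=C(O)Cn1nc(Cc2nc3cc(Cl)c(OCC(F)F)cc3[nH]2)c2ccccc2c1=O` gives 15 nM, far below both. Going by the values given here, the one measured step that changes a single place is a 23-fold higher number from compound 2 to compound 3 (1.36 log units; beyond the scatter), a step in the group on the oxygen of the aromatic ring.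

Compound 4 `O=C(O)Cn1nc(CC(=O)Nc2ccc(OC(F)(F)F)c(Cl)c2)c2ccccc2c1=O` differs from compound 1 by carboxy in place of methyl on a saturated chain carbon bound to an aromatic nitrogen. Among the compounds with values here, no measured pair covers this particular change: the step from compound 2 to compound 3 concerns a different position, and compound 2 and compound 3 already carry the carboxymethyl chain while differing from compound 1 in more than one place. Compound 3 shares the trifluoromethoxy and chloro substitution with compound 1 and compound 4, and its value sits close to that of compound 1, which offers weak support for expecting only a modest movement.

On these grounds the expected change is a 1.9-fold lower number from compound 1 to compound 4 (0.28 log units; within the scatter), with the direction uncertain and the size possibly within the scatter. Compound 4 is therefore estimated at 250 nM, within a range from 60 nM to 1000 nM.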

Compound 4, half-maximal inhibitory concentration: 754 nM
Estimate against measurement, compound 4: 3.0-fold (0.48 log units) below, within the range that was stated.
By their numbers in this assay, from the lowest: compound 2; then compounds 3, 1 and 4 (each within the scatter of the next, the first and the last beyond it).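

At this position, the change from ethyl to carboxymethyl on the core of compound 1 has now been measured directly, and in this assay it comes to a 1.6-fold higher number from compound 1 to compound 4 (0.20 log units; within the scatter), so the two compounds cannot be put in any order. The entering carboxy group adds heavy atoms, a hydrogen-bond donor and a hydrogen-bond acceptor, yet this single pair shows no difference that can be told apart from repeated measurement. The carboxymethyl chain, which compound 2 and compound 3 also carry, therefore has no readable effect of its own in this one pair, and this finding applies only to the core of compound 1. Nothing measured beyond these potency numbers bears on why the pair reads this way.

On these data alone, whether a longer chain ending in a carboxylic acid, an amine or a primary amide on a saturated chain carbon bound to an aromatic nitrogen would read the same stays open. As far as these compounds go, it is also open whether ethyl and carboxymethyl would stay as close on the core of compound 2, where the group on the oxygen moved the number so strongly.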